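A few compounds are considered here, and "the series" means these few. Any claim that something is new, unique, unknown or untested is made for them only; others in the source may bear on it.

Of the compounds shown here, two of a shared core have been tested in a functional assay on WHCO1 cells (Homo sapiens) for cytotoxicity, read by MTT assay, with a stated time of 24 h; on this read-out lower numbers stand for stronger inhibition and higher numbers for weaker inhibition. Compound 1 `O=C1C=C(C(O)c2ccc(Cl)cc2)C(=O)c2ccccc21` gives 3000 nM. Compound 2 `O=C1C=C(C(O)c2cccc(F)c2)C(=O)c2ccccc21` gives 5500 nM. Compound 2 holds the higher of the two numbers, but the step of a 1.8-fold higher number from compound 1 to compound 2 (0.26 log units; within the scatter) is within the scatter, so the two compounds cannot be told apart on these data. Compound 3 `O=C1C=C(C(O)c2ccoc2)C(=O)c2ccccc21` has not yet been measured. It differs from compound 2 by furan-3-yl in place of 3-fluorophenyl on a saturated chain carbon bound to a double-bonded ring carbon and an oxygen on a saturated carbon. For the measured compounds named here, the only measured step at this position, a 1.8-fold higher number from compound 1 to compound 2 (0.26 log units; within the scatter), swaps one six-membered aromatic ring for another and says little about a five-membered ring with an oxygen atom. With no step beyond the scatter on record, the expectation for compound 3 in this assay is a step of a 1.1-fold higher number from compound 2 to compound 3 (0.04 log units; within the scatter), that is, no clear change. Compound 3 is estimated at 6000 nM, with a range from 2500 nM to 15000 nM.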

Compound 3, half-maximal inhibitory concentration: 10900 nM
Compound 3: the middle estimate sits 1.8-fold (0.26 log units) below what was measured, and the stated range covers the measured number.
By their numbers in this assay, from the lowest: compounds 1, 2 and 3 (each within the scatter of the next, the first and the last beyond it).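

A swap at this position now moves the number beyond the usual scatter in this assay: furan-3-yl gives modestly weaker inhibition than 4-chlorophenyl (a 3.6-fold higher number from compound 1 to compound 3 (0.56 log units; beyond the scatter)). Furan-3-yl and 3-fluorophenyl still cannot be told apart (a 2.0-fold higher number from compound 2 to compound 3 (0.30 log units; within the scatter)), so among these three compounds, a five-membered aromatic ring with an oxygen atom costs little compared with the fluorinated six-membered ring. No measurement shown accounts for the difference between furan-3-yl and 4-chlorophenyl.

On these data alone, how an amine or a carboxylic acid on the ring, or a longer chain in place of the ring, would read in this assay stays open. The oxygen on the saturated carbon and the shared core are the same in all three compounds, so their part in the read-out is open too.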